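The source may report more compounds than this note shows. Statements on the series, on what has been measured and on what is new or still open speak of the compounds shown alone.

Measured compounds:
Compound 1 `COC(=O)[C@@]1(C)CC[C@@H]2C3=C1CC[C@@H](C)[C@]3(C)Cc1c2[nH]c2ccc(C)cc12` gives 11000 nM in a functional assay on HBL-100 cells (Homo sapiens) for inhibition, read by sulforhodamine B assay, with a stated time of 48 h; on this read-out higher numbers stand for weaker inhibition of growth and lower numbers for stronger inhibition of growth.
Compound 2 `COC(=O)[C@@]1(C)CC[C@@H]2C3=C1CC[C@@H](C)[C@]3(C)Cc1c2[nH]c2ccc(Br)cc12` gives 16000 nM.
Compound 3 `COC(=O)[C@@]1(C)CC[C@@H]2C3=C1CC[C@@H](C)[C@]3(C)C[C@@H]1c3cccc(C)c3N[C@H]21` gives 32000 nM.

Compound 1 and compound 2 share a core and differ by bromo in place of methyl on an aromatic carbon; the step is a 1.5-fold higher number from compound 1 to compound 2 (0.16 log units; within the scatter). Compound 3 has a different core; the difference between the two cores is not broken down here. Compound 4 `COC(=O)[C@@]1(C)CC[C@@H]2C3=C1CC[C@@H](C)[C@]3(C)C[C@@H]1c3cccc(Br)c3N[C@H]21` is not yet measured and differs from compound 3 by bromo in place of methyl on an aromatic carbon. The place differs from that in compound 2, where the group sits meta to a fused ring and para to a fused ring, while in compound 4 it sits ortho to a fused ring and meta to a fused ring, so this is the same kind of change, not the same. For the measured compounds named here, for compound 4 the expected step is a 1.4-fold higher number from compound 3 to compound 4 (0.15 log units; within the scatter), set beside the single comparable pair, because a 1.5-fold higher number from compound 1 to compound 2 (0.16 log units; within the scatter) showed little movement. Compound 4 is therefore estimated at 45000 nM, with a range from 20000 nM to 100000 nM.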

Compound 4, concentration for 50% growth inhibition: 40000 nM
The estimate for compound 4 lay 1.1-fold (0.05 log units) above the measured number, and the stated range covers the measured number.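

In this assay, bromo in place of methyl on an aromatic carbon gives a 1.3-fold higher number from compound 3 to compound 4 (0.10 log units; within the scatter). Set beside the earlier pair, the change reads alike on the two cores: the same change on two cores in this assay, a 1.5-fold higher number (0.16 log units; within the scatter) from compound 1 to compound 2 and a 1.3-fold higher number (0.10 log units; within the scatter) from compound 3 to compound 4, 1.2-fold (0.07 log units) apart, within the scatter of two such steps. This shows that in these two pairs, with the group at a different place in each, the exchange stayed within the scatter on both cores; it does not show that the same would hold on any other core, and two such small steps cannot separate a contribution of the core from one of the place.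

The compounds shown leave open whether a group other than methyl or bromo at these places, such as an amine, a carboxylic acid or a longer chain, would move the number beyond the scatter. They also leave open what replacing the methyl ester that all four compounds share would do.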